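The source may hold more compounds than are shown below. What is called first, only, known or untested is meant among the compounds shown, and "the series" means these compounds.

Compound 1 `CCOC(=O)c1c(C)[nH]c(=O)c(C#N)c1-c1ccccc1`: 22000 nM
Compound 2 `CCOC(=O)c1c(C)[nH]c(=O)c(C#N)c1-c1ccc(C)cc1`: 8000 nM
Compound 3 `CCOC(=O)c1c(C)[nH]c(=O)c(C#N)c1-c1ccc(OC)cc1`: 36100 nM

These three compounds share one core and differ only in the group on the six-membered aromatic ring of carbon only. In a functional assay on MCF7 cells (Homo sapiens) for inhibition, read by MTT assay, with a stated time of 24 h (a lower number here means a stronger inhibitor, a higher number a weaker inhibitor), compound 1 gives 22000 nM, compound 2 gives 8000 nM and compound 3 gives 36100 nM. Compound 2 stands lowest of the three and is thus the strongest inhibitor here: the step of a 2.8-fold lower number from compound 1 to compound 2 (0.44 log units; beyond the scatter) lies beyond the scatter, and so does the step of a 4.5-fold higher number from compound 2 to compound 3 (0.65 log units; beyond the scatter). Compound 4 `CCOC(=O)c1c(C)[nH]c(=O)c(C#N)c1-c1ccc([N+](=O)[O-])cc1` has not yet been measured. It differs from compound 2 by nitro in place of methyl on an aromatic carbon. The two measured steps that bear on this change are a 2.8-fold lower number from compound 1 to compound 2 (0.44 log units; beyond the scatter) and a 4.5-fold higher number from compound 2 to compound 3 (0.65 log units; beyond the scatter); both are modest and run in opposite directions. Nitro resembles neither methyl nor methoxy, so the direction is uncertain, but because a 4.5-fold higher number from compound 2 to compound 3 (0.65 log units; beyond the scatter) is the only measured replacement of methyl and it raised the number, a small rise is expected, a 1.9-fold higher number from compound 2 to compound 4 (0.27 log units; within the scatter). Compound 4 is therefore expected to give 15000 nM, with a likely range from 4000 nM to 60000 nM.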

Compound 4, half-maximal inhibitory concentration: 82000 nM
Estimate against measurement, compound 4: 5.5-fold (0.74 log units) below; the whole stated range lies below it.
By their numbers in this assay, from the lowest: compound 2; then compounds 1 and 3 (each within the scatter of the next); then compound 4.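

For the compounds shown here, this position can shift the number much further than the earlier compounds showed: a 10-fold higher number from compound 2 to compound 4 (1.01 log units; beyond the scatter) is a large step, whereas every earlier step was modest or within the scatter. In this assay compound 4 is the weakest inhibitor of the four, as the other two steps also lie beyond the scatter, namely a 3.7-fold higher number from compound 1 to compound 4 (0.57 log units; beyond the scatter) and a 2.3-fold higher number from compound 3 to compound 4 (0.36 log units; beyond the scatter), so a group placed here can weaken inhibition as well as strengthen it, as methyl did in compound 2. Nothing at hand explains why nitro gives this result.

Going by these compounds, whether an amine, a carboxylic acid or a chlorine atom at this place would land nearer compound 2 or compound 4 stays open. On these data alone, it is also open whether a longer chain such as ethyl would improve on compound 2 at 8000 nM.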